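The source may hold more compounds than are shown below. What is called first, only, known or untested is meant among the compounds shown, and "the series" means these compounds.

Compound 1 `Nc1ccccc1NC(=O)c1ccc(CSC(=S)N2CCN(c3ccncc3)CC2)cc1` gives 85.7% in a functional assay on A-375 cells (Homo sapiens) for antiproliferative activity, read by CCK-8 assay, with a stated time of 72 h, tested at 2 uM; a lower number here means a weaker effect, a higher number a stronger effect of the compound at the concentration tested.
Compound 2 `Nc1ccccc1NC(=O)c1ccc(CSC(=S)N2CCN(Cc3ccccc3)CC2)cc1` gives 10.6% in this assay.
Compound 3 `Nc1ccccc1NC(=O)c1ccc(CSC(=S)N2CCN(c3cccnc3)CC2)cc1` gives 40.5% in this assay.

Compound 3 stands second highest of these three numbers, beyond the scatter from both others: a number 29.9 percentage points higher from compound 2 to compound 3 (beyond the scatter), and a number 45.2 percentage points lower from compound 1 to compound 3 (beyond the scatter).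

Compound 4 `Nc1ccccc1NC(=O)c1ccc(CSC(=S)N2CCN(Cc3cccnc3)CC2)cc1` is the next step. It differs from compound 3 only at one place: (pyridin-3-yl)methyl in place of pyridin-3-yl on an amine nitrogen in a ring. Among the compounds with values here, two measured steps bear on this. In a number 75.1 percentage points lower from compound 1 to compound 2 (beyond the scatter) the ring on the piperazine nitrogen became a benzyl, and in a number 29.9 percentage points higher from compound 2 to compound 3 (beyond the scatter) a benzyl gave way to a pyridin-3-yl. In both, the compound whose ring sits on a methylene has the lower number, and the sizes were large and modest. A drop beyond the scatter is therefore expected for compound 4, about a number 22.5 percentage points lower from compound 3 to compound 4 (beyond the scatter). Compound 4 is estimated at 18%, between 5% and 38%.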

Compound 4, a percentage reported as inhibition, at one concentration (the size of the read-out at that concentration, not a potency): 31.5%
Compound 4: middle estimate off by 13.5 percentage points, on the low side; low and high end bracket the measured number.
By their numbers in this assay, from the lowest: compound 2; then compounds 4 and 3 (each within the scatter of the next); then compound 1.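

In this assay the step of a number 9 percentage points lower from compound 3 to compound 4 (within the scatter) shows that turning pyridin-3-yl into (pyridin-3-yl)methyl makes no readable difference. With the methylene kept, the ring's hetero atom does count, as a number 20.9 percentage points higher from compound 2 to compound 4 (beyond the scatter) shows for pyridin-3-yl in place of phenyl. Even so, the step of a number 54.2 percentage points lower from compound 1 to compound 4 (beyond the scatter) leaves (pyridin-3-yl)methyl far short of pyridin-4-yl on this amine nitrogen.

On these data alone, whether (pyridin-4-yl)methyl or pyridin-2-yl would come close to compound 1 stays open. Nothing measured here explains these steps.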